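The source may report more compounds than this note shows. Statements on the series, on what has been measured and on what is new or still open speak of the compounds shown alone.

Of the compounds shown here, three that share one core have been measured in a functional assay on U2OS cells for antagonist activity at proto-oncogene Wnt-3 (Homo sapiens), read by a luciferase reporter, with a stated time of 18 h; a lower number here means that less compound is needed, a higher number that more compound is needed for the effect. Compound 1 `O=C(CN1CCNCC1)N1CCC(NS(=O)(=O)c2cc(S(=O)(=O)c3ccccc3)ccc2C(F)(F)F)CC1` gives 250 nM in this assay. Compound 2 `CC(C)(C)CC(=O)N1CCC[C@H]1C(=O)N1CCC(NS(=O)(=O)c2cc(S(=O)(=O)c3ccccc3)ccc2C(F)(F)F)CC1` gives 120 nM, and compound 3 `O=C([C@@H]1CCCN1C(=O)c1ccncc1)N1CCC(NS(=O)(=O)c2cc(S(=O)(=O)c3ccccc3)ccc2C(F)(F)F)CC1` gives 350 nM. Of these three numbers compound 3 has the highest; its gap to compound 1 lies within the scatter, while its gap to compound 2 lies beyond it. Compound 4 `O=C([C@@H]1CCCN1Cc1ccccc1)N1CCC(NS(=O)(=O)c2cc(S(=O)(=O)c3ccccc3)ccc2C(F)(F)F)CC1` has not yet been measured in this assay. The change from compound 3 to compound 4 is benzyl in place of (pyridin-4-yl)carbonyl on an amine nitrogen in a ring. Going by the values given here, two measured steps bear on it: a 2.1-fold lower number from compound 1 to compound 2 (0.32 log units; beyond the scatter) and a 2.9-fold higher number from compound 2 to compound 3 (0.46 log units; beyond the scatter). Both were modest, and both altered the group that sits on a carbonyl carbon, whereas in compound 4 the carbonyl itself is gone, so neither step matches the change closely. The step from compound 2 to compound 3 brought in pyridin-4-yl and went to a higher number, and the change to compound 4 moves away from pyridin-4-yl again. On that basis compound 4 is expected to give a somewhat lower number, 200 nM, within 70 nM to 600 nM. The expected step is a 1.8-fold lower number from compound 3 to compound 4 (0.24 log units; within the scatter).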

Compound 4, half-maximal effective concentration: 720 nM
Compound 4: middle estimate off by 3.6-fold (0.56 log units), on the low side; measured number outside the range, above it.
By their numbers in this assay, from the lowest: compound 2; then compounds 1 and 3 (each within the scatter of the next); then compound 4.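

The group on the amine nitrogen of the five-membered non-aromatic ring can push the number up as well as down: in this assay, benzyl in place of (pyridin-4-yl)carbonyl gives a 2.1-fold higher number from compound 3 to compound 4 (0.31 log units; beyond the scatter), so moving away from pyridin-4-yl did not by itself bring the number down. The gap is wider against the other carbonyl-linked group, with benzyl in place of neopentylcarbonyl giving a 6.0-fold higher number from compound 2 to compound 4 (0.78 log units; beyond the scatter), so among the three groups shown on this nitrogen the order from lowest number is neopentylcarbonyl, (pyridin-4-yl)carbonyl, benzyl, and both groups that hold a carbonyl there give lower numbers than the one that does not. The 1-benzylpyrrolidin-2-yl group also compares poorly with the simpler (piperazin-1-yl)methyl on the carbonyl carbon, at a 2.9-fold higher number from compound 1 to compound 4 (0.46 log units; beyond the scatter), so adding this ring with its benzyl group brings no gain in this assay.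

Nothing given here accounts for the higher number of compound 4. A benzoyl group on the same nitrogen would keep the carbonyl and carry a carbon-only ring, and so would help separate the loss of the carbonyl from the loss of the ring nitrogen, which the change from compound 3 to compound 4 alters together.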